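The source may hold more compounds than are shown below. What is called first, only, known or untested is meant among the compounds shown, and "the series" means these compounds.

Of the compounds shown here, three have been measured in a physicochemical assay for solubility (on this read-out lower numbers stand for lower solubility and higher numbers for higher solubility), so far, and each result is a limit of the assay rather than a number. Compound 1 `CNC(=O)c1cc(C(=O)N[C@H]2[C@@H]3COC[C@@H]32)c([C@@H](C)c2ccccc2)o1` gives >= 131 ug/mL. Compound 3 `CNC(=O)c1cc(C(=O)N[C@H]2CC[C@H](O)CC2)c([C@@H](C)c2ccccc2)o1` gives >= 184 ug/mL. Compound 2 `CCNC(=O)c1cc(C(=O)NC)nn1[C@@H](C)c1ccccc1`, the starting point here, gives >= 137 ug/mL. Going by the values given here, the only step between measured compounds that differ in one place, a step that the two limits leave unreadable from compound 1 to compound 3, is therefore unreadable, since both ends sit at limits (the limit of >= 131 ug/mL in this assay, at which 1 of the 3 values shown sits, and (the limit of >= 184 ug/mL in this assay, at which 1 of the 3 values shown sits)). Compound 2 thus stands at a limit like the other two (the limit of >= 137 ug/mL in this assay, at which 1 of the 3 values shown sits), with nothing separating the three values.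

Compound 4 `CNC(=O)c1cc(C(=O)N[C@H]2CC[C@H](OC)CC2)n([C@@H](C)c2ccccc2)n1` carries the change (4-methoxycyclohexyl in place of ethyl on an amide-type nitrogen). Among the compounds with values here, no measured step bears directly on this change; the one step that exists swaps one ring-bearing group for another on an amide-type nitrogen and is unreadable. The step from compound 2 to compound 4 is therefore estimated as an at least 1.3-fold lower number from compound 2 to compound 4 (0.13 log units; that floor lies within the scatter), with wide uncertainty. For compound 4 the expected value in this assay is 100 ug/mL, within a range from 30 ug/mL to 250 ug/mL.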

Compound 4, solubility: >= 161 ug/mL
Compound 4 gave a limit, no number (the forecaster's own chance of this, stated with the estimate: 45%); at least 1.6-fold (0.20 log units) between middle value and limit.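

Going by these compounds alone, compound 2 and compound 4 both sit at limits of this assay, and no step between them can be read. The compounds shown leave open how far any true value lies past its limit, and whether 4-methoxycyclohexyl in place of ethyl on an amide-type nitrogen changes the read-out at all.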